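The compounds below may be only part of what the source reports. "The series", "measured", "known", "first", "only" and "open" are said of these compounds alone.

Measured compounds:
compound 1 `COc1ccc2nc(-c3ccc(N/C=C\C(=O)c4ccc(OC)c([N+](=O)[O-])c4)cc3)sc2c1` gives 13600 nM
compound 2 `COc1cc(OC)c2sc(-c3ccc(N/C=C\C(=O)c4cc(OC)c(OC)c(OC)c4)c(C)c3)nc2c1` gives 14400 nM
compound 3 `COc1cc(OC)c2sc(-c3ccc(N/C=C\C(=O)c4cc(OC)c(OC)c(OC)c4)cc3)nc2c1` gives 21800 nM

All three numbers come from a functional assay on A549 cells (Homo sapiens) for antiproliferative activity, read by sulforhodamine B assay, with a stated time of 48 h (on this read-out higher numbers stand for weaker inhibition and lower numbers for stronger inhibition), and lie within the scatter of each other, so no order is drawn among them. The difference between the core of compound 1 and the core of compound 3 is not broken down here. From compound 3 to compound 2 the change is methyl in place of hydrogen on an aromatic carbon, and the step is a 1.5-fold lower number from compound 3 to compound 2 (0.18 log units; within the scatter). Compound 4 `COc1ccc2nc(-c3ccc(N/C=C\C(=O)c4ccc(OC)c([N+](=O)[O-])c4)c(C)c3)sc2c1` is not yet measured; it arises from compound 1 by methyl in place of hydrogen on an aromatic carbon. The surroundings of the place differ in wording, meta to a 6-methoxy-1,3-benzothiazol-2-yl group in one case and meta to a large group in the other, so this is the same kind of change, not the same. The expected step in this assay is a 1.2-fold lower number from compound 1 to compound 4 (0.09 log units; within the scatter), because compound 1 gives 13600 nM and the earlier step of a 1.5-fold lower number from compound 3 to compound 2 (0.18 log units; within the scatter) stays within the scatter. Compound 4 is estimated at 11000 nM, between 5000 nM and 25000 nM.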

Compound 4, half-maximal inhibitory concentration: 13600 nM
For compound 4 the middle estimate is 1.2-fold (0.09 log units) below the measured one; the measured number falls inside the stated range.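

In this assay the methyl in place of hydrogen gives no change at the digits printed from compound 1 to compound 4 (within the scatter), and the two cores can be set side by side: the same change on two cores in this assay, a 1.5-fold lower number (0.18 log units; within the scatter) from compound 3 to compound 2 and no change at the digits printed (within the scatter) from compound 1 to compound 4, 1.5-fold (0.18 log units) apart, within the scatter of two such steps

Going by these compounds alone, the change thus carries from one core to the other with no step that stands out from the scatter on either core, and no difference between the cores can be read from these two pairs. This does not show that methyl is without effect on other cores or in other assays, and two pairs give no general rule.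

The compounds shown leave open whether another group at this place, such as ethyl, an amine or a carboxylic acid, would give a step beyond the scatter.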